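A few compounds are considered here, and "the series" means these few. Any claim that something is new, unique, unknown or untested is made for them only; others in the source may bear on it.

Compound 1 `CCCCNC(c1ccc(C2NC(=O)c3ccccc3N2)cc1)c1nnnn1C(C)(C)C`: "not determined" (no result reported)
Compound 2 `COc1cc(-c2cc(-c3ccc(C4NC(=O)c5ccccc5N4)cc3)nc(N)n2)cc(OC)c1OC`: 103000 nM

Among the compounds with values here, in an ADME assay on J774.A1 cells (Mus musculus) for cytotoxicity, read by MTT assay, with a stated time of 72 h (on this read-out higher numbers stand for lower toxicity in this test and lower numbers for higher toxicity in this test), compound 2 gives 103000 nM, the only number so far, so it cannot yet be ranked against anything. Compound 3 `Nc1nc(-c2ccc(Cl)cc2)cc(-c2ccc(C3NC(=O)c4ccccc4N3)cc2)n1` keeps the core of compound 2 and swaps one aryl group: 4-chlorophenyl in place of 3,4,5-trimethoxyphenyl on an aromatic carbon. Within the data shown here, no measured step exists to scale this change. A small step toward lower numbers in this assay, not clearly beyond the scatter, is expected. The estimated step of a 1.7-fold lower number from compound 2 to compound 3 (0.23 log units; within the scatter) therefore stays modest. For compound 3 the expected value is 60000 nM, with an estimated range of 15000 nM to 150000 nM.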

Compound 3, half-maximal cytotoxic concentration: 82200 nM
Compound 3: middle estimate off by 1.4-fold (0.14 log units), on the low side; the measured number falls inside the stated range.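

In this assay, 4-chlorophenyl in place of 3,4,5-trimethoxyphenyl on this aromatic carbon gives a 1.3-fold lower number from compound 2 to compound 3 (0.10 log units; within the scatter). Within the data shown here, the first measured step at this position therefore does not separate the two aryl groups, although the entering group has fewer heavy atoms and no hydrogen-bond acceptors. No supporting data bear on why the read-out stays within the scatter.

Still open, going by these compounds, is whether a non-aryl group on this carbon, such as an amine or a carboxylic acid, would give a step beyond the scatter. A replacement for the amino group also remains to be read against compound 2.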